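The source may report more compounds than this note shows. Statements on the series, on what has been measured and on what is new or still open speak of the compounds shown alone.

In a functional assay on the whole organism with Rattus norvegicus as the target (a lower number here means that less compound is needed, a higher number that more compound is needed for the effect), compound 1 (`CC(C)COc1ccccc1-c1ncc(-c2nn[nH]n2)c(O)n1`) gives 0.1 mg/kg and compound 2 (`Oc1nc(-c2ccccc2OCC2CC2)ncc1-c1nn[nH]n1`) gives 0.07 mg/kg. Compound 3 (`CCCOc1ccc(OC)cc1-c1ncc(-c2nn[nH]n2)c(O)n1`) gives 0.03 mg/kg, the lowest number of the three and clear of the scatter against both of the others. Compound 4 (`CCCOc1ccc(N(C)C)cc1-c1ncc(-c2nn[nH]n2)c(O)n1`) keeps the propoxy group of compound 3 and changes one thing: dimethylamino in place of methoxy on an aromatic carbon, para to a propoxy group (dimethylamino in place of methoxy on an aromatic carbon).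

Among the measured compounds shown here, only one measured step links two compounds that differ in a single place, and it is a 1.4-fold lower number from compound 1 to compound 2 (0.15 log units; within the scatter). That step exchanges isopropyl for cyclopropyl on the chain attached through oxygen, so it shows a small, within-scatter effect at a different place and says nothing directly about the new change. For the measured compounds named here, compound 3 is the only measured compound with methoxy, but its chain on oxygen also differs from those of compound 1 and compound 2, so its lower number cannot be assigned to either group.

Going by the values given here, no measured pair tests a replacement of methoxy, so no step beyond the scatter is expected in this assay. The expected size of the change is a 1.3-fold higher number from compound 3 to compound 4 (0.12 log units; within the scatter), a small estimate with no firm direction behind it. For compound 4 the estimated value is 0.04 mg/kg, with an expected range from 0.012 mg/kg to 0.12 mg/kg.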

Compound 4, dose for 50% inhibition: 0.4 mg/kg
Estimate against measurement, compound 4: 10-fold (1.00 log units) below; measured number above the stated range.
By their numbers in this assay, from the lowest: compound 3; then compounds 2 and 1 (each within the scatter of the next); then compound 4.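

In this assay, the ring carbon para to a propoxy group proves sensitive to what it carries: dimethylamino in place of methoxy gives a 13-fold higher number from compound 3 to compound 4 (1.12 log units; beyond the scatter), so much more compound is needed for the same effect. Among the compounds shown here, this is the first exchange in a single place that clearly moves the dose, and it shows that the good result of compound 3 does not survive every change at this carbon. For the compounds shown here, the only earlier comparison of this kind, a 1.4-fold lower number from compound 1 to compound 2 (0.15 log units; within the scatter), concerned another place, the chain on oxygen, and stayed within the scatter. Nothing measured for these compounds accounts for the rise.

The compounds shown do not separate the two parts of the exchange, a nitrogen for an oxygen and an extra carbon, and a smaller amine such as methylamino, or an ethyl group, at the same carbon would help to tell them apart. As far as these compounds go, it also stays open whether dimethylamino would bring a similar rise on another chain, such as the cyclopropyl-bearing chain of compound 2, or whether the step belongs to the propoxy series alone.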